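A new side chain on compound 3

The source may report more compounds than this note shows. Statements on the series, on what has been measured and on what is new or still open speak of the compounds shown alone.

In a functional assay on BGC-823 cells (Homo sapiens) for cytotoxicity, read by MTT assay, with a stated time of 24 h; on this read-out higher numbers stand for weaker inhibition and lower numbers for stronger inhibition:
- Compound 1 `CC[C@H](C)[C@@H](NC(=O)Cn1cc(C2=C(c3c[nH]c4ccccc34)C(=O)N(C)C2=O)c2ccccc21)C(=O)OC`: > 100000 nM (a limit, not a number)
- Compound 2 `COC(=O)[C@@H](C)NC(=O)Cn1cc(C2=C(c3c[nH]c4ccccc34)C(=O)N(C)C2=O)c2ccccc21`: 60400 nM
- Compound 3 `COC(=O)[C@H](NC(=O)Cn1cc(C2=C(c3c[nH]c4ccccc34)C(=O)N(C)C2=O)c2ccccc21)C(C)C`: 48200 nM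

Only two of these are true numbers, and they lie within the scatter of each other, so compound 3 stands level with compound 2.

Compound 4 `COC(=O)C[C@@H](NC(=O)Cn1cc(C2=C(c3c[nH]c4ccccc34)C(=O)N(C)C2=O)c2ccccc21)C(=O)OC` differs from compound 3 at one place: (methoxycarbonyl)methyl in place of isopropyl on a saturated chain carbon bound to an amide-type nitrogen and a carbonyl carbon. In words, (methoxycarbonyl)methyl comes in place of isopropyl on a saturated chain carbon bound to an amide-type nitrogen and a carbonyl carbon.

The measured changes on this same carbon are the guide. Putting isopropyl in place of methyl gave a 1.3-fold lower number from compound 2 to compound 3 (0.10 log units; within the scatter). Putting methyl in place of sec-butyl gave an at least 1.6-fold lower number from compound 1 to compound 2 (0.21 log units; that floor lies within the scatter). The one gap beyond the scatter is an at least 2.0-fold lower number from compound 1 to compound 3 (0.31 log units; beyond the scatter), and it starts from a limit.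

Going by the values given here, no measured compound carries the incoming group, so the range stays wide. No clear shift in either direction is expected in this assay, and the estimated step is a 1.0-fold higher number from compound 3 to compound 4 (0.02 log units; within the scatter).

For compound 4 the expected value is 50000 nM, with an estimated range from 20000 nM to 120000 nM.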

Compound 4, half-maximal inhibitory concentration: 24600 nM
Beside the measured number, compound 4's estimate is 2.0-fold (0.31 log units) above it, and the stated range covers the measured number.
By their numbers in this assay, from the lowest: compounds 4, 3 and 2 (each within the scatter of the next, the first and the last beyond it). At a limit, above all of these: compound 1.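

In this assay, a side chain carrying an ester, (methoxycarbonyl)methyl, can stand on this carbon without any loss, and the change from isopropyl is a 2.0-fold lower number from compound 3 to compound 4 (0.29 log units; within the scatter), so it gives no clear gain on that comparison. Set against the small methyl side chain, the same ester chain gives a 2.5-fold lower number from compound 2 to compound 4 (0.39 log units; beyond the scatter), the first gap between two true numbers in this set that lies beyond the scatter. The step that starts from a limit rather than a true number is an at least 4.0-fold lower number from compound 1 to compound 4 (0.60 log units; beyond the scatter), and its real size stays unknown: the limit of > 100000 nM in this assay, at which 1 of the 4 values shown sits.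

Still open, going by these compounds, is whether the ester itself matters here or simply the length of the side chain. A carboxylic acid, an amine or a longer chain ending in the same ester on this carbon would test that.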